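Series notes: third methoxy, from compound 3 to compound 4

This account rests on a few compounds, and the source may have more. Where it says the series, first, only, none or still open, it means among the compounds named here.

In a functional assay on HeLa cells (Homo sapiens) for antiproliferative activity, read by sulforhodamine B assay, with a stated time of 48 h (a higher number here means a weaker inhibitor of growth, a lower number a stronger inhibitor of growth), the measured compounds stand as follows. Compound 1 `O=C(NCc1cn(Cc2ccc(F)cc2)nn1)c1cn(-c2ccccc2)nc1-c1ccccc1` gives 1600 nM. Compound 2 `O=C(NCc1cn(Cc2ccc(Cl)cc2)nn1)c1cn(-c2ccccc2)nc1-c1ccccc1` gives 600 nM. Compound 3 `COc1ccc(Cn2cc(CNC(=O)c3cn(-c4ccccc4)nc3-c3ccccc3)nn2)cc1OC` gives 10800 nM.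

Compound 3 holds the highest number of the three: a 6.8-fold higher number from compound 1 to compound 3 (0.83 log units; beyond the scatter) and an 18-fold higher number from compound 2 to compound 3 (1.26 log units; beyond the scatter), while a 2.7-fold lower number from compound 1 to compound 2 (0.43 log units; beyond the scatter).

Compound 4 `COc1cc(Cn2cc(CNC(=O)c3cn(-c4ccccc4)nc3-c3ccccc3)nn2)cc(OC)c1OC` differs from compound 3 by methoxy in place of hydrogen on an aromatic carbon. Among the compounds with values here, no measured step adds a methoxy to a ring that already carries methoxy groups; the nearest steps, from compound 1 and compound 2 to compound 3, only show that the 3,4-dimethoxyphenyl raised the number beyond the scatter. A further methoxy gives no direction to expect, so the estimate stays near compound 3 with a wide range.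

Compound 4 is expected at 10000 nM, between 3000 nM and 35000 nM. The expected step is a 1.1-fold lower number from compound 3 to compound 4 (0.03 log units; within the scatter), within the scatter.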

Compound 4, concentration for 50% growth inhibition: > 100000 nM
Compound 4: only a limit was reported; the forecaster's own chance of this, stated with the estimate: 15%; at least 10-fold (1.00 log units) between middle value and limit.
By their numbers in this assay, from the lowest: compound 2; then compound 1; then compound 3. At a limit, above all of these: compound 4.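

In this assay compound 4 gives only a limit, not a number: the limit of > 100000 nM in this assay, at which 1 of the 4 values shown sits. Adding a third methoxy to the dimethoxyphenyl ring is not neutral at this position, giving an at least 9.2-fold higher number from compound 3 to compound 4 (0.96 log units; beyond the scatter). Against the halogenated rings, the 3,4,5-trimethoxyphenyl group gives an at least 160-fold higher number from compound 2 to compound 4 (2.22 log units; beyond the scatter) and an at least 62-fold higher number from compound 1 to compound 4 (1.79 log units; beyond the scatter), so the number climbs across these compounds as methoxy groups accumulate on this ring.

From the compounds shown here alone, the size of the step to compound 4 stays unknown beyond its limit. Going by these compounds, whether a single methoxy, a hydroxyl or an amine on this ring would stay near compound 2 remains open.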